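The source may hold more compounds than are shown below. What is called first, only, known or untested is meant among the compounds shown, and "the series" means these compounds.

Measured compounds:
compound 1 `Cc1ccc(NC(=S)NC(=O)c2cn(-c3ccccc3)nc2-c2ccc(F)cc2)cc1` — 2980 nM in a functional assay on NCI-H460 cells (Homo sapiens) for inhibition, read by CCK-8 assay, with a stated time of 48 h; a higher number here means a weaker inhibitor, a lower number a stronger inhibitor
compound 2 `Cc1ccc(NC(=S)NC(=O)c2cn(-c3ccccc3)nc2-c2ccc(Cl)cc2)cc1` — 3120 nM
compound 3 `COc1ccc(-c2nn(-c3ccccc3)cc2C(=O)NC(=S)Nc2ccc(F)cc2)cc1` — 3050 nM

Compound 1 sits at the same level as compounds 2 and 3; the three numbers lie within the scatter of one another, so no order among them can be read. Compound 4 `O=C(NC(=S)Nc1ccc(Cl)cc1)c1cn(-c2ccccc2)nc1-c1ccc(F)cc1` is not yet measured; relative to compound 1 it carries chloro in place of methyl on an aromatic carbon. Among the measured compounds shown here, no measured pair shows this exchange. For the measured compounds named here, the only single-point step known is a 1.0-fold higher number from compound 1 to compound 2 (0.02 log units; within the scatter), a halogen exchange elsewhere in the molecule, which left the number unchanged. Compound 3, which differs from compound 1 in two places, also gives a number within the scatter of compound 1. Going by the values given here, nothing so far has moved this assay beyond the scatter, so for compound 4 a step of a 1.0-fold higher number from compound 1 to compound 4 (0.00 log units; within the scatter) is expected, meaning none beyond the scatter. The estimate for compound 4 is 3000 nM, range 1500 nM to 6000 nM.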

Compound 4, half-maximal inhibitory concentration: 3090 nM
Beside the measured number, compound 4's estimate is 1.0-fold (0.01 log units) below it, and the stated range covers the measured number.
By their numbers in this assay, from the lowest: compounds 1, 3, 4 and 2 (each within the scatter of the next).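

In this assay, 4-methylphenyl to 4-chlorophenyl gives a 1.0-fold higher number from compound 1 to compound 4 (0.02 log units; within the scatter), the only single change shown at this position. Methyl and chloro on this aromatic carbon, para to a large group, therefore cannot be told apart by this read-out, which adds to the earlier halogen exchange at the other end of the molecule. No measurement at hand offers a reason for this.

As far as these compounds go, whether an amine, a carboxylic acid or a longer chain at this position would move the number beyond the scatter remains open. Also open, from the compounds shown here alone, is whether the two aromatic rings elsewhere on the shared core would respond to such groups.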